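Third chloro on the aryl ring: expectation for compound 3

The source may hold more compounds than are shown below. What is called first, only, known or untested is meant among the compounds shown, and "the series" means these compounds.

Compound 1 `N#CC1=C(N)Oc2c(N)cc3nc4ccccc4nc3c2C12C(=O)N(Cc1cnnn1-c1ccc(F)cc1)c1ccccc12` carries a 4-fluorophenyl on an aromatic nitrogen. In a functional assay on MCF7 cells (Homo sapiens) for antiproliferative activity, read by MTT assay, with a stated time of 48 h (a higher number here means a weaker inhibitor, a lower number a stronger inhibitor), compound 1 gives only a limit of the assay, > 50000 nM. Compound 2 `N#CC1=C(N)Oc2c(N)cc3nc4ccccc4nc3c2C12C(=O)N(Cc1cnnn1-c1ccc(Cl)cc1Cl)c1ccccc12` has 2,4-dichlorophenyl in place of 4-fluorophenyl on an aromatic nitrogen. In this assay compound 2 likewise gives only a limit, > 50000 nM. The step that the two limits leave unreadable from compound 1 to compound 2 therefore has no readable size, and compound 2 stands at the limit of > 50000 nM in this assay, at which 2 of the 2 values shown sit, with no number of its own.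

Compound 3 `N#CC1=C(N)Oc2c(N)cc3nc4ccccc4nc3c2C12C(=O)N(Cc1cnnn1-c1c(Cl)cc(Cl)cc1Cl)c1ccccc12` differs from compound 2 in one place: chloro in place of hydrogen on an aromatic carbon. For the measured compounds named here, no measured step bears on this change, as the single step runs from one limit to another. The expectation for compound 3 rests only on the position of compound 2 at the limit of > 50000 nM in this assay, at which 2 of the 2 values shown sit. Compound 3 is thus expected in this assay to give about 50000 nM, within 20000 nM to 100000 nM, most likely again as a limit rather than a number. The step of a number no higher from compound 2 to compound 3 (the limit leaves the size open) is accordingly estimated as none beyond the scatter.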

Compound 3, half-maximal inhibitory concentration: 37800 nM
Compound 3: middle estimate off by 1.3-fold (0.12 log units), on the high side; the measured number falls inside the stated range.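

In this assay, for the compounds shown here, compound 3 is the first of the series to give a number rather than a limit, which makes the aromatic carbon ortho to a large group the first place on this aryl ring where a change can be followed. Chloro in place of hydrogen there gives an at least 1.3-fold lower number from compound 2 to compound 3 (0.12 log units; that floor lies within the scatter), and the full change from the 4-fluorophenyl gives an at least 1.3-fold lower number from compound 1 to compound 3 (0.12 log units; that floor lies within the scatter). Both floors leave the true size open, and the step from compound 1 to compound 2 cannot be read, as each of those two compounds gives only a limit: the limit of > 50000 nM in this assay, at which 2 of the 3 values shown sit.

Open, on these data alone, is whether methyl, methoxy or an amine on that same aromatic carbon would also give a number in this assay. Also open, as far as these compounds go, is whether chloro there gives a number without the two chloro groups it is meta to.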